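Swapping an amide for a sulfonamide: cytotoxicity outlook

This account rests on a few compounds, and the source may have more. Where it says the series, first, only, none or still open, it means among the compounds named here.

Compound 2 `COc1ccc(C(=O)Nc2ncc(C(Oc3ccc4cc(Br)ccc4c3)c3ccc(Cl)cc3)s2)cc1` was tested in an ADME assay on HepG2 2.2.15 cells (Homo sapiens) for cytotoxicity; on this read-out lower numbers stand for higher toxicity in this test and higher numbers for lower toxicity in this test. In this assay compound 2 gives > 50000 nM, which is a limit of the assay rather than a number. Compound 1 `CC(C)(C)OC(=O)Nc1ncc(C(Oc2ccc3cc(Br)ccc3c2)c2ccc(Cl)cc2)s1` differs from compound 2 only by a tert-butoxy in place of a 4-methoxyphenyl on a carbonyl carbon. In this assay compound 1 gives > 50000 nM, again a limit. The step that the two limits leave unreadable from compound 1 to compound 2 is unreadable because of the limit of > 50000 nM in this assay, at which 2 of the 2 values shown sit. Compound 3 `Cc1ccc(C)c(S(=O)(=O)Nc2ncc(C(Oc3ccc4cc(Br)ccc4c3)c3ccc(Cl)cc3)s2)c1` carries (2,5-dimethylphenyl)sulfonyl in place of (4-methoxyphenyl)carbonyl on a nitrogen on an aromatic ring. For the measured compounds named here, no measured step reads as a number, so none of them gives a direction for this change. With both measured compounds sitting at the same limit, compound 3 is expected to show a step of a number no higher from compound 2 to compound 3 (the limit leaves the size open), that is, no change beyond the scatter. Compound 3 is therefore estimated at 50000 nM, within a range from 20000 nM to 100000 nM, most likely reported once more as a limit.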

Compound 3, half-maximal cytotoxic concentration: > 50000 nM
Compound 3 was reported as a limit; the forecaster's own chance of this, stated with the estimate: 70%; the middle value sits exactly at the limit.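

No step among compound 1, compound 2 and compound 3 can be read in this assay, because all three stop at a limit of the assay: the limit of > 50000 nM in this assay, at which 3 of the 3 values shown sit.

The compounds shown leave open whether their half-maximal cytotoxic concentrations differ, and so whether the (2,5-dimethylphenyl)sulfonyl in compound 3 changes this read-out.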